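A Piperidinylpropyl Chain Replaces the Ester in Compound 1

The source may report more compounds than this note shows. Statements on the series, on what has been measured and on what is new or still open speak of the compounds shown alone.

The compounds here share one core, an oxime ether carrying two aromatic groups, and differ only in the chain attached to the oxime oxygen. Compound 1 `CCOC(=O)CO/N=C(\c1ccc(SC)cc1)c1cccc2ccccc12` carries an ethoxycarbonyl group on that chain; in a functional assay on HeLa cells (Homo sapiens) for antiproliferative activity, read by MTT assay, with a stated time of 24 h (a lower number here means that less compound is needed, a higher number that more compound is needed for the effect), compound 1 gives 18000 nM. Among the two compounds with a numerical result, compound 1 has the lowest number, but the only neighbour sits close to it: compound 2 `CCN(CC)C(=O)CO/N=C(\c1ccc(SC)cc1)c1cccc2ccccc12` gives 25000 nM, and the step of a 1.4-fold higher number from compound 1 to compound 2 (0.14 log units; within the scatter) stays within the scatter. Compound 3 `CCCCC(CC)CNCCCO/N=C(\c1ccc(OC)cc1)c1cccc2ccccc12`, which carries a methoxy group in place of the methylthio group and a long amine-bearing chain, reaches only a limit of the assay, > 50000 nM, as noted in the limit of > 50000 nM in this assay, at which 1 of the 3 values shown sits.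

Compound 4 `CSc1ccc(/C(=N\OCCCCN2CCCCC2)c2cccc3ccccc23)cc1` is the next design. Its change from compound 1 is 3-(piperidin-1-yl)propyl in place of ethoxycarbonyl on a saturated chain carbon bound to an oxygen on an unsaturated carbon. Among the measured compounds shown here, no measured step tracks this exact change; the one measured step, from ester to amide, was within the scatter, and compound 3, the only amine-bearing example, differs from compound 1 in two places and shows only a limit. The expectation for this assay is therefore uncertain, and compound 4 is expected near 14000 nM, within a range of 3500 nM to 50000 nM, an estimated step of a 1.3-fold lower number from compound 1 to compound 4 (0.11 log units; within the scatter).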

Compound 4, half-maximal effective concentration: 18000 nM
Compound 4: middle estimate off by 1.3-fold (0.11 log units), on the low side, and the stated range covers the measured number.
By their numbers in this assay, from the lowest: compounds 1, 4 and 2 (each within the scatter of the next). At a limit, above all of these: compound 3.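

Putting 3-(piperidin-1-yl)propyl on the saturated chain carbon bound to an oxygen on an unsaturated carbon removes the carbonyl and adds a nitrogen and a six-membered non-aromatic ring, yet this assay shows no change at the digits printed from compound 1 to compound 4 (within the scatter) and, against the amide, a 1.4-fold lower number from compound 2 to compound 4 (0.14 log units; within the scatter) in the same range. Among the compounds shown here, the earlier step compared only two carbonyl-bearing groups, whereas compounds 1, 2 and 4 now show that this place accepts a carbonyl-free group with a ring and a much larger heavy-atom count without a shift beyond the scatter. Compound 3 also carries an amine but differs from compound 1 in two places. Compound 3 gives > 50000 nM, which is a limit of the assay, so it gives no readable step and does not test this pattern.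

Nothing shown here gives a cause for the unchanged number. On these data alone, it remains open whether a carboxylic acid, a morpholine ring or a shorter chain ending in piperidine in this place would carry the number beyond the scatter, and whether any such change would behave the same way with methoxy in place of methylthio.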